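The source may report more compounds than this note shows. Statements on the series, on what has been measured and on what is new or still open speak of the compounds shown alone.

Of the compounds shown here, three built on one shared core have been measured so far. Compound 1 `O=C(Nc1ccc(Oc2ccnc3[nH]ccc23)c(F)c1)c1nn(-c2ccccc2)ccc1=O` gives 34900 nM in a functional assay on MCF7 cells (Homo sapiens) for cytotoxicity, read by MTT assay, with a stated time of 72 h; on this read-out higher numbers stand for weaker inhibition and lower numbers for stronger inhibition. Compound 2 `Cn1ccc2c(Oc3ccc(NC(=O)c4nn(-c5ccccc5)ccc4=O)cc3)ccnc21` gives 45200 nM in this assay. Compound 3 `Cn1ccc2c(Oc3ccc(NC(=O)c4nn(-c5ccc(Cl)cc5)ccc4=O)cc3F)ccnc21` carries a 4-chlorophenyl group, and for compound 3 this assay reports no number, only a limit, > 60000 nM. Compound 3 therefore stands apart from compound 1 and compound 2 in that its result is one of those sitting at the limit of the assay (the limit of > 60000 nM in this assay, at which 1 of the 3 values shown sits).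

Compound 4 `Cn1ccc2c(Oc3ccc(NC(=O)c4nn(-c5ccccc5)ccc4=O)cc3F)ccnc21` has not yet been measured. Going from compound 3 to compound 4 means (hydrogen in place of chloro on an aromatic carbon). No pair of measured compounds differs in exactly this way, so the size of the step cannot be read from the numbers shown. Still, a step toward stronger inhibition of about an at least 1.3-fold lower number from compound 3 to compound 4 (0.12 log units; that floor lies within the scatter) is expected, because compound 2 with the same phenyl group gives 45200 nM. For compound 4 in this assay the expected value is 45000 nM, within a range from 20000 nM to 90000 nM.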

Compound 4, half-maximal inhibitory concentration: > 60000 nM
Compound 4: a limit, no number; the forecaster's own chance of this, stated with the estimate: 30%; middle value at least 1.3-fold (0.12 log units) away from the limit.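

Replacing 4-chlorophenyl with phenyl does not bring the result inside the measurable range, and the step between compound 3 and compound 4 cannot be read: the limit of > 60000 nM in this assay, at which 2 of the 4 values shown sit. The other comparisons add only a little: fluoro in place of hydrogen on an aromatic carbon gives an at least 1.3-fold higher number from compound 2 to compound 4 (0.12 log units; that floor lies within the scatter) and methyl in place of hydrogen on an aromatic nitrogen gives an at least 1.7-fold higher number from compound 1 to compound 4 (0.23 log units; that floor lies within the scatter). Each of these is only a floor that lies within the scatter, so neither change is shown to weaken inhibition, although the true value of compound 4 could lie further out.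

As far as these compounds go, whether an amine or a methoxy group in place of the chloro would give a number in this assay stays open. So does how far past the limit compound 3 and compound 4 really lie.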